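The source may hold more compounds than are shown below. What is called first, only, known or untested is meant among the compounds shown, and "the series" means these compounds.

Working notes on the series, all read in a functional assay for inhibition, with Homo sapiens as the target; on this read-out higher numbers stand for weaker inhibition and lower numbers for stronger inhibition. Compound 1 `CCOC(=O)/C(=C\c1cccc(OCC(=O)OC(C)(C)C)c1)c1nc(-c2ccccc2)c(-c2ccccc2)o1` is reported only as a limit, > 60000 nM. Compound 2 `CCOC(=O)/C(=C\c1cccc(OCC(=O)O)c1OC)c1nc(-c2ccccc2)c(-c2ccccc2)o1` gives 130 nM. Compound 3 `C[S+]([O-])C(Cc1cccc(OCC(=O)O)c1)c1nc(-c2ccccc2)c(-c2ccccc2)o1` gives 7080 nM, the higher of the two true numbers in hand and beyond the scatter from compound 2.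

Compound 4 `O=C(O)COc1cccc(CC(CCO)c2nc(-c3ccccc3)c(-c3ccccc3)o2)c1` has not yet been measured. Its difference from compound 3 is a group of 3 heavy atoms (2 carbon, 1 oxygen; no ring) in place of a group of 3 heavy atoms (1 carbon, 1 oxygen, 1 sulfur; no ring), on a saturated chain carbon bound to an aromatic carbon and a saturated chain carbon: a 2-hydroxyethyl group in place of a group of 3 heavy atoms, on a saturated chain carbon bound to an aromatic carbon and a saturated chain carbon. Among the compounds with values here, no measured pair isolates this exchange, so the size of the step in this assay is poorly constrained. A moderate fall in the number is expected, beyond the scatter but not reaching as low as compound 2. The lower of the two true numbers in hand belongs to compound 2, which gives 130 nM. The expected change is a 3.9-fold lower number from compound 3 to compound 4 (0.59 log units; beyond the scatter). For compound 4 the estimate is 1800 nM, with an expected range of 300 nM to 10000 nM.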

Compound 4, half-maximal inhibitory concentration: 2920 nM
For compound 4 the middle estimate is 1.6-fold (0.21 log units) below the measured one; the range from low to high includes it.
By their numbers in this assay, from the lowest: compound 2; then compound 4; then compound 3. At a limit, above all of these: compound 1.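

In this assay the exchange reads as a 2.4-fold lower number from compound 3 to compound 4 (0.38 log units; beyond the scatter) and gives the first view of this position, a saturated chain carbon bound to an aromatic carbon and a saturated chain carbon. The 2-hydroxyethyl group, with its hydrogen-bond donor, can stand in place of the sulfur-containing group with a modest fall in the number, so activity at this position does not depend on sulfur. Nothing in hand accounts for the size of this step.

As far as these compounds go, whether the hydroxyl or the carbon chain carries the step stays open, and a plain ethyl group, a longer chain ending in hydroxyl or an amine at this position would separate the two. Compound 2 differs from compound 4 in more than one place, so it does not settle how low this position can take the number.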